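Exchanging an ether chain for an aminopropylamino chain

This account rests on a few compounds, and the source may have more. Where it says the series, first, only, none or still open, it means among the compounds named here.

Compound 2 `COCCOc1cc2c(NC3CCCCC3)ncnc2cn1` carries a 2-methoxyethoxy chain on the shared core. In a functional assay on CHO cells for antagonist activity at metabotropic glutamate receptor 1 (Rattus norvegicus), with a stated time of 5 min (a higher number here means a weaker inhibitor, a lower number a stronger inhibitor), compound 2 gives 101 nM, the second highest of the three numbers measured. Compound 1 `OCCOc1cc2c(NC3CCCCC3)ncnc2cn1` gives 177 nM, and the step of a 1.8-fold lower number from compound 1 to compound 2 (0.24 log units; within the scatter) is small. Compound 3 `O=C1CCCN1CCOc1cc2c(NC3CCCCC3)ncnc2cn1` gives 20 nM; the steps of a 5.1-fold lower number from compound 2 to compound 3 (0.70 log units; beyond the scatter) and an 8.9-fold lower number from compound 1 to compound 3 (0.95 log units; beyond the scatter) are modest gains. Compound 4 `NCCCNc1cc2c(NC3CCCCC3)ncnc2cn1` differs from compound 2 by (3-aminopropyl)amino in place of 2-methoxyethoxy on an aromatic carbon. For the measured compounds named here, none of the measured steps swaps the whole chain as this one does; each alters one part of it and moves the number modestly or not at all, so they bear on this change only loosely. The step of a 1.5-fold higher number from compound 2 to compound 4 (0.17 log units; within the scatter) is therefore expected to be small. Compound 4 is estimated at 150 nM, with a range from 40 nM to 600 nM.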

Compound 4, inhibition constant: 200 nM
The estimate for compound 4 lay 1.3-fold (0.12 log units) below the measured number, within the range that was stated.
By their numbers in this assay, from the lowest: compound 3; then compounds 2, 1 and 4 (each within the scatter of the next).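

The steps of a 2.0-fold higher number from compound 2 to compound 4 (0.30 log units; within the scatter) and a 1.1-fold higher number from compound 1 to compound 4 (0.05 log units; within the scatter) both stay within the scatter, so exchanging the whole chain on this aromatic carbon leaves no clear change in this assay here. The earlier compounds shown here altered only the end of an oxygen-linked chain, whereas this exchange also replaces the oxygen on the aromatic carbon with a nitrogen and brings in hydrogen-bond donors. No measurement shown explains this result.

Still open, from the compounds shown here alone, is whether the linking nitrogen or the end amine matters more, which a (3-hydroxypropyl)amino chain could separate. A longer chain or a carboxylic acid at the chain end also remains untested among the compounds shown.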